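From Compound 2 to Compound 3: One Group Exchanged

The source may hold more compounds than are shown below. What is called first, only, known or untested is meant among the compounds shown, and "the series" means these compounds.

Of the compounds shown here, two built on one shared core have numbers so far in a functional assay on MCF7 cells (Homo sapiens) for antiproliferative activity, read by MTT assay, with a stated time of 72 h; on this read-out lower numbers stand for stronger inhibition and higher numbers for weaker inhibition. There, compound 1 `O=S(=O)(Oc1ccc(Br)cc1)C1CC2OC1C(c1ccc(/C=C/c3cc(O)cc(O)c3)cc1)=C2c1ccc(O)cc1` gives 16900 nM, and compound 2 `O=S(=O)(Oc1cccc(C(F)(F)F)c1)C1CC2OC1C(c1ccc(/C=C/c3cc(O)cc(O)c3)cc1)=C2c1ccc(O)cc1` gives 11500 nM. These two values lie within the usual scatter of each other, so compound 2 cannot be ranked against compound 1.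

The next structure, compound 3 `O=S(=O)(Oc1ccc(-c2ccccc2)cc1)C1CC2OC1C(c1ccc(/C=C/c3cc(O)cc(O)c3)cc1)=C2c1ccc(O)cc1`, keeps the core and changes one group on an oxygen: 4-phenylphenyl in place of 3-(trifluoromethyl)phenyl on an oxygen. In words, 4-phenylphenyl takes the place of 3-(trifluoromethyl)phenyl. For the measured compounds named here, only one measured step bears on this oxygen, a 1.5-fold lower number from compound 1 to compound 2 (0.17 log units; within the scatter), and it stays within the scatter. Going by the values given here, that step is a thin guide, since no measured compound carries 4-phenylphenyl. With nothing else to go on, no shift beyond the scatter is expected in this assay, and neither direction can be favoured. The expected step is a 1.0-fold higher number from compound 2 to compound 3 (0.02 log units; within the scatter). For compound 3 the estimated value is 12000 nM, with an expected range from 6000 nM to 25000 nM.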

Compound 3, half-maximal inhibitory concentration: 7800 nM
Estimate against measurement, compound 3: 1.5-fold (0.19 log units) above; measured number inside the range.
By their numbers in this assay, from the lowest: compounds 3, 2 and 1 (each within the scatter of the next, the first and the last beyond it).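

In this assay the exchange of 3-(trifluoromethyl)phenyl for 4-phenylphenyl on the oxygen gives a 1.5-fold lower number from compound 2 to compound 3 (0.17 log units; within the scatter) and so, taken alone, cannot be told apart from the normal spread of repeated measurements. The comparison with compound 1 says more: phenyl in place of bromo on an aromatic carbon gives a 2.2-fold lower number from compound 1 to compound 3 (0.34 log units; beyond the scatter) and is the first step among these compounds to pass beyond the scatter, although only modestly, showing that a second aromatic ring at this spot is compatible with the activity seen so far and can even bring a small gain over bromo. Nothing available explains this small gain.

On these data alone, all three groups on this oxygen are aromatic rings, so it remains open how the number would respond to a plain phenyl with no further group, or to a simple alkyl chain in place of the ring. As far as these compounds go, it is also open whether an amine or a carboxylic acid on the outer phenyl of 4-phenylphenyl would extend the modest gain or reverse it.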